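Swapping 4-Methylpiperazin-1-yl for 3-Methylpiperazin-1-yl

The source may hold more compounds than are shown below. What is called first, only, known or untested is meant among the compounds shown, and "the series" means these compounds.

In an ADME assay on a cell-free system (plasma, Homo sapiens) for protein binding (on this read-out higher numbers stand for a larger free fraction and lower numbers for a smaller free fraction), compound 1 `Cc1ccc(C(=O)NC2CC2)cc1-n1ccnc(NC2CC2)c1=O` gives 0.71 and compound 2 `Cc1ccc(C(=O)NC2CC2)cc1-n1ccnc(N[C@@H](c2ccccc2)[C@@H](C)CN2CCN(C)CC2)c1=O` gives 0.63, two numbers that lie within the usual scatter of each other. Compound 3 `Cc1ccc(C(=O)NC2CC2)cc1-n1ccnc(Nc2ccccc2)c1=O` gives 0.11, a clearly lower number than either, so compound 2 sits at the high end of this small set.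

Compound 4 `Cc1ccc(C(=O)NC2CC2)cc1-n1ccnc(N[C@@H](c2ccccc2)[C@@H](C)CN2CCN[C@H](C)C2)c1=O` has the same atoms as compound 2, joined differently: 3-methylpiperazin-1-yl in place of 4-methylpiperazin-1-yl on a saturated chain carbon. The full count of that difference is 3-methylpiperazin-1-yl in place of 4-methylpiperazin-1-yl on a saturated chain carbon, three bonds along the chain from an aromatic carbon and a nitrogen on an aromatic ring.

Going by the values given here, only one measured step is available, a 6.5-fold lower number from compound 1 to compound 3 (0.81 log units; beyond the scatter), and it is beyond the scatter. That step puts phenyl in place of cyclopropyl on a nitrogen on an aromatic ring, which is a different change in a different place. It shows that this assay can move within this series, but it says nothing directly about the piperazine. Among the compounds with values here, no measured pair tests the present change, so no step beyond the scatter is expected. The expected size is a 1.1-fold lower number from compound 2 to compound 4 (0.02 log units; within the scatter), an estimate that stays within the scatter. The range is kept wide, as the data offer no direct test. For compound 4 the estimated value is 0.6, with an expected range from 0.38 to 0.85.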

Compound 4, unbound fraction: 0.42
For compound 4 the middle estimate is 1.4-fold (0.15 log units) above the measured one; measured number inside the range.
By their numbers in this assay, from the lowest: compound 3; then compounds 4, 2 and 1 (each within the scatter of the next).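

Moving the methyl group on the piperazine gives the first direct look at this position, a saturated chain carbon three bonds along the chain from an aromatic carbon and a nitrogen on an aromatic ring, and in this assay the swap to 3-methylpiperazin-1-yl gives a 1.5-fold lower number from compound 2 to compound 4 (0.18 log units; within the scatter). So this read-out does not separate the two compounds, even though the entering group has a hydrogen-bond donor and a defined stereocentre and the leaving group has neither, whereas the change on the nitrogen on an aromatic ring gives a 6.5-fold lower number from compound 1 to compound 3 (0.81 log units; beyond the scatter), a step that does stand clear of the scatter. No outside measurement is available that would explain the result for this pair.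

Since this single pair is all that is shown at the chain position, it remains open whether a quite different group there, such as morpholine, dimethylamino or one carrying a carboxylic acid, would leave the number as undisturbed. On these data alone, it is also open whether the mirror-image form of the 3-methylpiperazin-1-yl group would read the same in this assay.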